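Swapping a fluorophenyl tail for a methylthiazole: stability expected

The compounds below may be only part of what the source reports. "The series", "measured", "known", "first", "only" and "open" are said of these compounds alone.

Two members of this series, compound 1 `COc1ccc(CCOc2ccc(-c3c(C)nc(C)c([C@H](OC(C)(C)C)C(=O)O)c3N3CCC(C)(C)CC3)cc2)cc1` and compound 2 `Cc1nc(C)c([C@H](OC(C)(C)C)C(=O)O)c(N2CCC(C)(C)CC2)c1-c1ccc(OCCCc2ccc(F)cc2)cc1`, have been tested in an ADME assay on microsomes from liver (Rattus norvegicus) for metabolic stability, read by LC-MS, tested at 0.5 uM; on this read-out higher numbers stand for a longer-lived compound and lower numbers for a shorter-lived compound. For compound 1 the reading is only a limit of the assay, > 2 h. For compound 2 the reading is likewise only a limit, > 2 h. For the measured compounds named here, the single step between them, a step that the two limits leave unreadable from compound 1 to compound 2, cannot be sized because both readings sit at the limit of > 2 h in this assay, at which 2 of the 2 values shown sit. Going by the values given here, compound 2 thus stands at the limit, as does the only other value shown. Compound 3 `Cc1ncsc1CCOc1ccc(-c2c(C)nc(C)c([C@H](OC(C)(C)C)C(=O)O)c2N2CCC(C)(C)CC2)cc1` differs from compound 2 by 4-methyl-1,3-thiazol-5-yl in place of 4-fluorobenzyl on a saturated chain carbon, two bonds along the chain from an oxygen on an aromatic ring. Among the compounds with values here, no measured step bears directly on this change, and the one known step is unreadable. For compound 3 the expected step is a step that the limit leaves unreadable from compound 2 to compound 3, an expectation resting only on compound 2 sitting at its limit of > 2 h. Compound 3 is therefore estimated at 2.5 h in this assay, within a range from 1 h to 6 h.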

Compound 3, half-life: > 2 h
Compound 3 was reported as a limit (the forecaster's own chance of this, stated with the estimate: 60%); the middle value lies beyond the limit too.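

Compound 3 gives no readable step against compound 1 or compound 2, since all three readings stop at the same assay limit: the limit of > 2 h in this assay, at which 3 of the 3 values shown sit. Going by these compounds, how long each compound actually lasts in this assay stays open, and so does whether these tail changes alter the half-life at all.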